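This account rests on a few compounds, and the source may have more. Where it says the series, first, only, none or still open, it means among the compounds named here.

Of the compounds shown here, three have been measured in a functional assay on KM12 cells (Homo sapiens) for inhibition, read by sulforhodamine B assay, with a stated time of 48 h, tested at 1 uM; a lower number here means a stronger effect, a higher number a weaker effect of the compound at the concentration tested. Compound 1, `O=C(Nc1cccc(-n2cc(-c3ccncc3)c(-c3cc(O)cc(Cl)c3)n2)c1)Nc1ccc(Cl)c(C(F)(F)F)c1`, gives 56% in this assay. Compound 2, `COc1cc(Cl)cc(-c2nn(-c3cccc(NC(=O)Nc4ccc(Cl)c(C(F)(F)F)c4)c3)cc2-c2ccncc2)c1`, gives 33% in this assay, and compound 3, `COc1cc(Cl)cc(-c2nn(-c3cccc(NC(=O)Nc4cc(C(F)(F)F)cc(C(F)(F)F)c4)c3)cc2-c2ccncc2)c1`, gives 31% in this assay. Among these three numbers, compound 2 stands second highest; the value of compound 3 lies within the scatter of it, while compound 1 lies clearly above it. Among the measured compounds shown here, the single one-point step known so far, a number 23 percentage points lower from compound 1 to compound 2 (beyond the scatter), concerns a methyl in place of hydrogen on an oxygen on an aromatic ring and does not touch the urea part.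

Compound 4, `COc1cc(Cl)cc(-c2nn(-c3cccc(NC(=O)c4cccc(C(F)(F)F)c4)c3)cc2-c2ccncc2)c1`, has not yet been measured. It differs from compound 2 in one place: 3-(trifluoromethyl)phenyl in place of (4-chloro-3-(trifluoromethyl)phenyl)amino on a carbonyl carbon. For the measured compounds named here, no measured step describes such a change at the carbonyl carbon; the values of compound 2 and compound 3 show only that exchanging the substituents on the urea aryl leaves the number essentially unchanged. The change to compound 4 is larger than that, since it removes the amino group and its hydrogen-bond donor altogether. Compound 4 is therefore expected to show a modest weakening, a number 15 percentage points higher from compound 2 to compound 4 (beyond the scatter), with considerable uncertainty. Compound 4 is estimated at 48%, within a range of 28% to 72%.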

Compound 4, a percentage reported as activity, at one concentration (the size of the read-out at that concentration, not a potency): 56%
Beside the measured number, compound 4's estimate is 8 percentage points below it; measured number inside the range.
By their numbers in this assay, from the lowest: compounds 3 and 2 (each within the scatter of the next); then compounds 1 and 4 (each within the scatter of the next).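

In this assay, among the compounds shown here, placing 3-(trifluoromethyl)phenyl in place of (4-chloro-3-(trifluoromethyl)phenyl)amino on this carbonyl carbon gives a number 23 percentage points higher from compound 2 to compound 4 (beyond the scatter), which shows that the number responds to a change at this position, something the earlier compounds did not show because compound 2 and compound 3 lie within the scatter of each other. The group that leaves carries a nitrogen, a hydrogen-bond donor and a chlorine that the entering group lacks, so this one step covers all of these together and cannot be divided among them. Nothing available here accounts for the rise in the number at this change.

The compounds shown leave open how much of the step goes with the loss of the amino nitrogen and how much with the loss of the chlorine, a question that a (3-(trifluoromethyl)phenyl)amino group on the same carbonyl carbon would address. They also leave open whether an N-methylamino link or a methylene link to the aryl ring at this carbonyl carbon would give a number nearer that of compound 2 or that of compound 4.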